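A few compounds are considered here, and "the series" means these few. Any claim that something is new, unique, unknown or untested is made for them only; others in the source may bear on it.

Measured so far in a physicochemical assay for lipophilicity, read by mass spectrometry; a lower number here means a more polar compound, a higher number a more lipophilic compound:
compound 1 `COc1cc2c(cc1OC)C(=O)C(C(=O)Nc1ccc(Br)cc1)C2`: 3.03
compound 2 `COc1cc2c(cc1OC)C(=O)C(C(=O)Nc1cccc(Cl)c1)C2`: 2.76
compound 3 `COc1cc2c(cc1OC)C(=O)C(C(=O)Nc1ccccc1C)C2`: 2.69

Compound 3 stands at the low end of these three numbers, though it is not separated from compound 2. The closest measured step reads a number 0.07 log units lower from compound 2 to compound 3 (within the scatter), and the widest reads a number 0.34 log units lower from compound 1 to compound 3 (beyond the scatter).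

Next in the series is compound 4 `COc1cc2c(cc1OC)C(=O)C(C(=O)Nc1ccccc1F)C2`. It keeps the shared core and the amide and differs at one place: fluoro in place of methyl on an aromatic carbon. In words, this is fluoro in place of methyl on an aromatic carbon, ortho to a large group.

The measured steps that bear on this change are those that exchange one substituted phenyl for another on the amide-type nitrogen. Besides the two above, there is a number 0.27 log units lower from compound 1 to compound 2 (within the scatter). All three are small to modest, so a large step would be out of line with them. None of them involves a fluoro compound, so they limit the expected size but do not settle the direction. A slightly lower number is a judgement here, not a measured trend.

In this assay the expected step is a number 0.24 log units lower from compound 3 to compound 4 (within the scatter), and it may not clear the scatter.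

For compound 4 the estimated value is 2.45, with an expected range of 2.15 to 2.75.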

Compound 4, partition coefficient: 2.36
Compound 4: the middle estimate sits 0.09 log units above what was measured; measured number inside the range.
By their numbers in this assay, from the lowest: compound 4; then compounds 3, 2 and 1 (each within the scatter of the next, the first and the last beyond it).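

In this assay, fluoro in place of methyl on an aromatic carbon, ortho to a large group, gives a number 0.33 log units lower from compound 3 to compound 4 (beyond the scatter) in this series, the first step shown that involves a fluoro compound. Among the compounds shown here, the two wider steps read a number 0.40 log units lower from compound 2 to compound 4 (beyond the scatter) and a number 0.67 log units lower from compound 1 to compound 4 (beyond the scatter) and stretch the range across these substituted phenyl groups on the amide-type nitrogen beyond what the earlier steps showed. Compound 4 now holds the lowest number of the four, with its steps to all three others beyond the scatter, and the direction of the methyl to fluoro change is measured here for this one pair only.

Open, as far as these compounds go, is whether 2-chlorophenyl, 2-methoxyphenyl, or a phenyl carrying an amine or a carboxylic acid at the same place would fall in line with compound 3 and compound 4, and whether fluoro elsewhere on this ring would give a similar number. The data shown include no measurement that accounts for the size or direction of this step.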